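The compounds below may be only part of what the source reports. "The series", "measured", "known", "first", "only" and "open" are said of these compounds alone.

Three compounds have been measured:
compound 1, `O=C(NNC(=O)c1ccccc1Cl)c1ccc(NS(=O)(=O)c2cnc(O)nc2O)cc1`, 3240 nM
compound 2, `O=C(NNC(=O)c1cccc(Cl)c1)c1ccc(NS(=O)(=O)c2cnc(O)nc2O)cc1`, 8610 nM
compound 3, `O=C(NNC(=O)c1ccccc1Cl)c1cccc(NS(=O)(=O)c2cnc(O)nc2O)c1`, 6070 nM

All three were tested in a functional assay on SGC-7901 cells (Homo sapiens) for antiproliferative activity, read by MTT assay, with a stated time of 24 h; on this read-out lower numbers stand for stronger inhibition and higher numbers for weaker inhibition. Compound 1 and compound 2 share one core; compound 3 carries a different core, and the difference between the two cores is not broken down here. Compound 3 and compound 1 give numbers within the usual scatter of each other, as do compound 3 and compound 2, so no order among them can be read from these values alone.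

One change is seen in a measured pair and is now repeated on the other core. Going from compound 1 to compound 2 the change is 3-chlorophenyl in place of 2-chlorophenyl on a carbonyl carbon, and it gave a 2.7-fold higher number from compound 1 to compound 2 (0.42 log units; beyond the scatter). The not-yet-measured compound 4, `O=C(NNC(=O)c1cccc(NS(=O)(=O)c2cnc(O)nc2O)c1)c1cccc(Cl)c1`, differs from compound 3 by the same change, (3-chlorophenyl in place of 2-chlorophenyl on a carbonyl carbon). Because the step of a 2.7-fold higher number from compound 1 to compound 2 (0.42 log units; beyond the scatter) lay beyond the scatter, a similar step is expected here, and the number for compound 4 is estimated to move by a 2.5-fold higher number from compound 3 to compound 4 (0.39 log units; beyond the scatter). That rests on one measured pair only, so the range is wide. Compound 4 is therefore estimated at 15000 nM, between 6000 nM and 40000 nM.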

Compound 4, half-maximal inhibitory concentration: 7310 nM
Compound 4: the middle estimate sits 2.1-fold (0.31 log units) above what was measured; the measured number falls inside the stated range.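

In this assay, going by these compounds alone, the change to 3-chlorophenyl in place of 2-chlorophenyl on a carbonyl carbon gave a 1.2-fold higher number from compound 3 to compound 4 (0.08 log units; within the scatter), so on the core of compound 3 it leaves no step that can be told from the scatter. Set beside the earlier result, the two steps cannot be told apart: the same change on two cores in this assay, a 2.7-fold higher number (0.42 log units; beyond the scatter) from compound 1 to compound 2 and a 1.2-fold higher number (0.08 log units; within the scatter) from compound 3 to compound 4, 2.2-fold (0.34 log units) apart, within the scatter of two such steps. This shows that the step seen on the core of compound 1 need not reach the same clear size on the core of compound 3, but it does not show that the two cores respond differently, and with one pair on each core the change can be said neither to carry over nor to fail to carry over.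

As far as these compounds go, all four compounds carry a chlorophenyl group at this place, so it remains open how an amine, a methoxy group or a carboxylic acid in place of the chlorine would read on either core. From the compounds shown here alone, whether the step would be clear or vanish on a third core also remains open.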